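Swapping the hydroxyphenyl for a thiophene: expected effect

The compounds below may be only part of what the source reports. "The series", "measured", "known", "first", "only" and "open" are said of these compounds alone.

Of the compounds shown here, three sharing one core have been tested in a functional assay on BGC-823 cells (Homo sapiens) for cytotoxicity, read by MTT assay, with a stated time of 48 h; on this read-out lower numbers stand for stronger inhibition and higher numbers for weaker inhibition. Compound 1 `O=C(CSc1nnc(-c2ccncc2)o1)N/N=C/c1ccc(F)cc1` gives 17800 nM; compound 2 `O=C(CSc1nnc(-c2ccncc2)o1)N/N=C/c1ccc(O)cc1` gives 7940 nM; compound 3 `COc1cccc(/C=N/NC(=O)CSc2nnc(-c3ccncc3)o2)c1` gives 15800 nM. Compound 2 shows the lowest number of the three, but only its step from compound 1 is clear: a 2.2-fold lower number from compound 1 to compound 2 (0.35 log units; beyond the scatter). Its step to compound 3 is a 2.0-fold higher number from compound 2 to compound 3 (0.30 log units; within the scatter), and compound 1 against compound 3 is a 1.1-fold lower number from compound 1 to compound 3 (0.05 log units; within the scatter).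

Compound 4 `O=C(CSc1nnc(-c2ccncc2)o1)N/N=C/c1cccs1` has not yet been measured. It differs from compound 2 in one place: thiophen-2-yl in place of 4-hydroxyphenyl on a carbon with a double bond to nitrogen. The measured step that speaks most directly is the loss of the hydroxy group, since removing it in a 2.0-fold higher number from compound 2 to compound 3 (0.30 log units; within the scatter) and adding it in a 2.2-fold lower number from compound 1 to compound 2 (0.35 log units; beyond the scatter) both moved the number by about the same amount. On that basis compound 4 is expected to lose the advantage that compound 2 has and to land near compounds 1 and 3 in this assay. The expected step is a 1.8-fold higher number from compound 2 to compound 4 (0.25 log units; within the scatter). The estimate for compound 4 is 14000 nM, with a range from 6000 nM to 35000 nM.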

Compound 4, half-maximal inhibitory concentration: 26700 nM
Compound 4: the middle estimate sits 1.9-fold (0.28 log units) below what was measured, within the range that was stated.
By their numbers in this assay, from the lowest: compounds 2, 3, 1 and 4 (each within the scatter of the next, the first and the last beyond it).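

In this assay the change of ring on the carbon with a double bond to nitrogen can matter even without a change in net charge: thiophen-2-yl in place of 4-hydroxyphenyl gives a 3.4-fold higher number from compound 2 to compound 4 (0.53 log units; beyond the scatter) and this step lies clearly beyond the scatter. Thiophen-2-yl cannot be told apart from the other two rings, with a 1.7-fold higher number from compound 3 to compound 4 (0.23 log units; within the scatter) and a 1.5-fold higher number from compound 1 to compound 4 (0.18 log units; within the scatter) both within the scatter, so compound 4 joins compound 1 and compound 3 in one group, from which compound 2 is separated only in part. Nothing measured here gives a reason for these differences.

Open, going by these compounds, is whether a phenyl ring carrying an amine or a carboxylic acid would give a lower number than compound 2 does. Also open, on these data alone, is how a 3-hydroxyphenyl or a longer chain would behave at this place.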